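Cytotoxicity in HEL cells across four pyrazine carboxamides

The source may hold more compounds than are shown below. What is called first, only, known or untested is meant among the compounds shown, and "the series" means these compounds.

Measured so far:
compound 1 `CCCCCCCCNc1nccnc1C(=O)NCc1ccccc1`: > 100000 nM
compound 2 `CCCCNc1cnc(C(=O)NCc2ccccc2)cn1`: > 100000 nM
compound 3 `CCCCCCCCNc1cnc(C(=O)NCc2ccccc2)cn1`: 100000 nM

In an ADME assay on HEL cells (Homo sapiens) for cytotoxicity, read by microscopy, with a stated time of 6 days (on this read-out higher numbers stand for lower toxicity in this test and lower numbers for higher toxicity in this test), compound 1 gives > 100000 nM, which is a limit of the assay. Compound 2 likewise gives > 100000 nM, also a limit. Compound 3 gives 100000 nM. The step of a number no lower from compound 3 to compound 2 (the limit leaves the size open) is the change (hydrogen in place of butyl on a saturated chain carbon, four bonds along the chain from a nitrogen on an aromatic ring), and its size cannot be read because of the limit of > 100000 nM in this assay, at which 2 of the 3 values shown sit. The difference between the core of compound 1 and the core of compound 3 is not broken down here.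

Compound 4 `CCCCNc1nccnc1C(=O)NCc1ccccc1` has not yet been measured in this assay. It differs from compound 1 by hydrogen in place of butyl on a saturated chain carbon, four bonds along the chain from a nitrogen on an aromatic ring, the same change as from compound 3 to compound 2. The step is expected to be a number no higher from compound 1 to compound 4 (the limit leaves the size open), because compound 1 already sits at > 100000 nM and compound 3 gives 100000 nM. Compound 4 is therefore expected to give about 100000 nM, between 50000 nM and 200000 nM.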

Compound 4, minimum cytotoxic concentration: > 100000 nM
Compound 4 gave a limit, no number; the forecaster's own chance of this, stated with the estimate: 70%; the middle value lies on the limit itself.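

No new step can be read, as compound 1 and compound 4 each give only a limit, not a number, because of this: the limit of > 100000 nM in this assay, at which 3 of the 4 values shown sit.
The compounds shown leave open how large any change from butyl to hydrogen is on the core of compound 1.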